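This account rests on a few compounds, and the source may have more. Where it says the series, first, only, none or still open, it means among the compounds named here.

Measured compounds and their values:
Compound 1, `CCCCNc1nc(N)nc(C)c1CCCN(CC)CC`: 254 nM
Compound 2, `CCCCNc1nc(N)nc(C)c1CCCN1CCN(C(=O)OC(C)(C)C)CC1`: 300 nM

In an assay on HEK293 cells for agonist activity at Toll-like receptor 8 (Homo sapiens), read by spectrophotometry (a lower number here means that less compound is needed, a higher number that more compound is needed for the effect), compound 1 gives 254 nM and compound 2 gives 300 nM; the two numbers lie within the scatter of each other, so neither can be set apart from the other. Compound 3, `CCCCNc1nc(N)nc(C)c1CCCCCc1ccccc1`, is not yet measured. It differs from compound 1 in one place: phenethyl in place of diethylamino on a saturated chain carbon, three bonds along the chain from an aromatic carbon. Since compounds 1 and 2 show that two different groups at this position give much the same number, the step is expected to stay within the scatter or be small in either direction, a 1.2-fold lower number from compound 1 to compound 3 (0.06 log units; within the scatter). Compound 3 is therefore estimated at 220 nM, between 60 nM and 800 nM.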

Compound 3, half-maximal effective concentration: 830 nM
For compound 3 the middle estimate is 3.8-fold (0.58 log units) below the measured one; measured number outside the range, above it.
By their numbers in this assay, from the lowest: compounds 1 and 2 (each within the scatter of the next); then compound 3.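

In this assay, the position proved not to be indifferent to its group: phenethyl in place of diethylamino gives a 3.3-fold higher number from compound 1 to compound 3 (0.51 log units; beyond the scatter), whereas the groups of compounds 1 and 2 could not be set apart. Compound 3 carries an aromatic carbon ring and no nitrogen in this group, unlike both earlier compounds, but no available evidence explains the step. The compounds shown leave open whether the nitrogen or the ring matters, since phenethyl differs from diethylamino in both. A plain pentyl chain, or a pyridine ring in place of the phenyl, could separate the two.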